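A dichlorophenyl ring in place of pyridin-3-yl

The source may report more compounds than this note shows. Statements on the series, on what has been measured and on what is new or still open speak of the compounds shown alone.

Compound 1 `CCCCCCCCCCCCCCCCCCNC(=O)[C@H]1CSC(c2cccnc2)N1`: 10500 nM
Compound 2 `CCCCCCCCCCCCCCCCCCNC(=O)[C@H]1CSC(c2ccc(C#N)cc2)N1`: > 20000 nM, a limit of the assay
Compound 3 `CCCCCCCCCCCCCCCCCCNC(=O)[C@H]1CSC(c2cc(F)cc(F)c2)N1`: > 20000 nM, a limit of the assay

The three measured compounds share one core and differ only in the aromatic group on a saturated ring carbon. Within the data shown here, in a functional assay on RH7777 cells (Homo sapiens) for antiproliferative activity against RH7777 (Rattus norvegicus), read by sulforhodamine B assay (a lower number here means a stronger inhibitor, a higher number a weaker inhibitor), compound 1 gives 10500 nM, the only actual number among the three. Compound 2 stops at a limit of the assay, > 20000 nM. Compound 3 likewise stops at a limit, > 20000 nM. Most of the data thus sit at the limit of > 20000 nM in this assay, at which 2 of the 3 values shown sit. The steps away from compound 1 read an at least 1.9-fold higher number from compound 1 to compound 2 (0.27 log units; that floor lies within the scatter) and an at least 1.9-fold higher number from compound 1 to compound 3 (0.27 log units; that floor lies within the scatter), and between the two limits the step is a step that the two limits leave unreadable from compound 2 to compound 3.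

Compound 4 `CCCCCCCCCCCCCCCCCCNC(=O)[C@H]1CSC(c2c(Cl)cccc2Cl)N1` carries the change (2,6-dichlorophenyl in place of pyridin-3-yl on a saturated ring carbon). Both earlier replacements of pyridin-3-yl by a ring of carbon only, an at least 1.9-fold higher number from compound 1 to compound 2 (0.27 log units; that floor lies within the scatter) and an at least 1.9-fold higher number from compound 1 to compound 3 (0.27 log units; that floor lies within the scatter), ended at the limit of the assay, and the same direction is expected for this third carbon-only ring, though the size cannot be read from the data. Compound 4 is therefore expected to give about 25000 nM in this assay, with a range from 9000 nM to 60000 nM. That estimate corresponds to a 2.4-fold higher number from compound 1 to compound 4 (0.38 log units; beyond the scatter), and the result is expected most probably as a limit rather than a number.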

Compound 4, half-maximal inhibitory concentration: > 20000 nM
Compound 4: no number, only a limit (the forecaster's own chance of this, stated with the estimate: 65%); the middle value lies beyond the limit too.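

With compound 4, three different rings of carbon only, carrying a nitrile, fluorine or chlorine, have now been placed on this saturated ring carbon, and none gives a number in this assay; the pyridin-3-yl ring of compound 1 remains the only group shown that does. The new comparison gives an at least 1.9-fold higher number from compound 1 to compound 4 (0.27 log units; that floor lies within the scatter), so the true gap may be larger, but these values alone do not establish a difference beyond the scatter, and the steps among compounds 2, 3 and 4 cannot be read. The 2,6-dichlorophenyl result adds one more value to the group that can no longer be ranked: the limit of > 20000 nM in this assay, at which 3 of the 4 values shown sit.

On these data alone, it remains open whether the ring nitrogen of pyridin-3-yl is what sets compound 1 apart, a question that a pyridin-4-yl ring or an unsubstituted phenyl ring on the same carbon could help answer. Also open, as far as these compounds go, is whether a phenyl ring carrying an amine or a carboxylic acid would give a readable number in this assay, and how that number would compare with compound 1 at 10500 nM.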